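Aryl hydrazone variation on the shared core: compound 4

This account rests on a few compounds, and the source may have more. Where it says the series, first, only, none or still open, it means among the compounds named here.

Measured so far:
compound 1 `COc1ccc(OC)c(/C=N/NC(=O)Nc2ccc(Oc3ccnc(-c4nncn4CCN(C)C)c3)c(F)c2)c1`: 2070 nM
compound 2 `CN(C)CCn1cnnc1-c1cc(Oc2ccc(NC(=O)N/N=C/c3ccc(O)c(F)c3)cc2F)ccn1`: 3310 nM
compound 3 `CN(C)CCn1cnnc1-c1cc(Oc2ccc(NC(=O)N/N=C/c3ccc(O)cc3O)cc2F)ccn1`: 52600 nM

All three were read in a functional assay on HT-29 cells (Homo sapiens) for cytotoxicity, read by MTT assay, with a stated time of 72 h; a higher number here means a weaker inhibitor, a lower number a stronger inhibitor. Compound 1 gives the lowest number of the three; its nearest neighbour is compound 2, at a 1.6-fold higher number from compound 1 to compound 2 (0.20 log units; within the scatter), its furthest compound 3, at a 25-fold higher number from compound 1 to compound 3 (1.41 log units; beyond the scatter). Compound 4 `Cc1cc(/C=N/NC(=O)Nc2ccc(Oc3ccnc(-c4nncn4CCN(C)C)c3)c(F)c2)cc(C)c1O` is not yet measured; relative to compound 1 the change is 4-hydroxy-3,5-dimethylphenyl in place of 2,5-dimethoxyphenyl on a carbon with a double bond to nitrogen. For the measured compounds named here, the steps that bear on it are the two other replacements of the 2,5-dimethoxyphenyl: the 3-fluoro-4-hydroxyphenyl of compound 2 stayed within the scatter, whereas the 2,4-dihydroxyphenyl of compound 3 was a large loss, also seen as a 16-fold higher number from compound 2 to compound 3 (1.20 log units; beyond the scatter). Compound 4 carries one hydroxyl, as compound 2 does, rather than the two of compound 3. For compound 4 the expected step is therefore a 1.2-fold higher number from compound 1 to compound 4 (0.08 log units; within the scatter), within or near the scatter. The estimate for compound 4 is 2500 nM, with a range of 900 nM to 8000 nM.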

Compound 4, half-maximal inhibitory concentration: 1220 nM
Beside the measured number, compound 4's estimate is 2.0-fold (0.31 log units) above it; the range from low to high includes it.
By their numbers in this assay, from the lowest: compounds 4, 1 and 2 (each within the scatter of the next, the first and the last beyond it); then compound 3.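

In this assay, the 4-hydroxy-3,5-dimethylphenyl group holds the level of the 2,5-dimethoxyphenyl group, a 1.7-fold lower number from compound 1 to compound 4 (0.23 log units; within the scatter), so this place accepts a hydroxyl-bearing ring with two methyl groups. The same group gives a modest gain over the 3-fluoro-4-hydroxyphenyl group, a 2.7-fold lower number from compound 2 to compound 4 (0.43 log units; beyond the scatter), and a large one over the 2,4-dihydroxyphenyl group, a 43-fold lower number from compound 3 to compound 4 (1.63 log units; beyond the scatter), so a hydroxyl alone does not bring the loss seen with compound 3. No measurement at hand accounts for these steps. The compounds shown do not separate the share of the hydroxyl from that of the methyl groups. As far as these compounds go, how an amine or a carboxylic acid on this ring would fare remains open.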